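The compounds below may be only part of what the source reports. "The series", "measured", "known", "first", "only" and "open" are said of these compounds alone.

Among the compounds with values here, compound 2 `COc1cc(N)c(Cl)cc1NC(=O)C1CCN(Cc2ccccc2)CC1` is the only compound with a number in a functional assay on the whole organism for antagonist activity, with Mus musculus as the target (on this read-out lower numbers stand for an effect already at smaller amounts and higher numbers for an effect only at larger amounts of compound), where compound 2 gives 0.5 mg/kg. Compound 1 `COc1cc(N)c(Cl)cc1NC(=O)C1CCN(CC2CCCCCC2)CC1` reached only a limit of the assay, > 10 mg/kg. The step of an at least 20-fold lower number from compound 1 to compound 2 (1.30 log units; beyond the scatter) came with phenyl in place of cycloheptyl on a saturated chain carbon bound to an amine nitrogen in a ring. Compound 3 `COc1cc(N)c(Cl)cc1NC(=O)C1CCN(Cc2ccc(OCc3ccccc3)cc2)CC1` differs from compound 2 by benzyloxy in place of hydrogen on an aromatic carbon. Within the data shown here, no measured step adds a group to this aromatic ring, so the one earlier step gives no direct guide; the expected change is modest, a 2.0-fold higher number from compound 2 to compound 3 (0.30 log units; within the scatter). Compound 3 is expected to give 1 mg/kg, between 0.3 mg/kg and 5 mg/kg.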

Compound 3, dose for half-maximal effect: > 4 mg/kg
Compound 3: a limit, no number; the forecaster's own chance of this, stated with the estimate: 15%; middle value at least 4.0-fold (0.60 log units) away from the limit.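

In this assay, benzyloxy in place of hydrogen on this aromatic carbon, para to a large group, gives an at least 8.0-fold higher number from compound 2 to compound 3 (0.90 log units; beyond the scatter). Within the data shown here, this is the first look at a group added to the phenyl ring itself, and here the added benzyloxy is not tolerated as hydrogen is, whereas the earlier step only exchanged cycloheptyl for phenyl. The value of compound 3 is a limit of the assay, so the step gives only a minimum size: the limit of > 4 mg/kg in this assay, at which 1 of the 3 values shown sits.

As far as these compounds go, whether a smaller group here, such as methoxy or a single fluorine atom, would keep the activity of compound 2 remains open. So does whether a benzyl group without the oxygen would behave like benzyloxy.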